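The compounds below may be only part of what the source reports. "The series", "measured", "known", "first", "only" and "open" are said of these compounds alone.

Measured compounds in a functional assay on MCF7 cells (Homo sapiens) for antiproliferative activity, read by MTT assay, with a stated time of 48 h; on this read-out higher numbers stand for weaker inhibition and lower numbers for stronger inhibition:
- compound 1 `N#CC1=C(N)Oc2c(c3nc4ccccc4nc3c3ccccc23)C12C(=O)N(Cc1cnnn1-c1ccc(Cl)cc1)c1ccccc12`: compound 1 gives > 50000 nM, which is a limit of the assay, not a number.
- compound 2 `N#CC1=C(N)Oc2c(c3nc4ccccc4nc3c3ccccc23)C12C(=O)N(Cc1cnnn1-c1ccc(S(N)(=O)=O)cc1)c1ccccc12`: compound 2 gives > 50000 nM, again only a limit of the assay.
- compound 3 `N#CC1=C(N)Oc2c(c3nc4ccccc4nc3c3ccccc23)C12C(=O)N(Cc1cnnn1-c1cccc(S(N)(=O)=O)c1)c1ccccc12`: compound 3 gives 42500 nM.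

Compound 1 stands only at a limit on these numbers; it is one of the two values that sit at the limit of > 50000 nM in this assay, at which 2 of the 3 values shown sit. The step that the two limits leave unreadable from compound 1 to compound 2 therefore cannot be read, and the step of an at least 1.1-fold lower number from compound 1 to compound 3 (0.07 log units; that floor lies within the scatter) tells nothing beyond the scatter. The step of an at least 1.1-fold lower number from compound 2 to compound 3 (0.07 log units; that floor lies within the scatter) is of the same kind. In this assay, going by the values given here, nothing measured so far separates the three compounds.

Compound 4 `N#CC1=C(N)Oc2c(c3nc4ccccc4nc3c3ccccc23)C12C(=O)N(Cc1cnnn1-c1cc(Cl)ccc1Cl)c1ccccc12` is not yet measured. It differs from compound 1 in one place: 2,5-dichlorophenyl in place of 4-chlorophenyl on an aromatic nitrogen. Among the compounds with values here, none of the measured steps touches a dichlorophenyl group; the nearest changes, to a sulfamoylphenyl in compound 2 and compound 3, left the numbers where they were. No step measured here gives a reason to expect movement, so compound 4 is expected to sit close to compound 1, with the step that the limit leaves unreadable from compound 1 to compound 4 estimated to lie within the scatter. The estimate for compound 4 is 55000 nM, with a range from 20000 nM to 150000 nM, and it is expected that this assay may again report only a limit.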

Compound 4, half-maximal inhibitory concentration: > 50000 nM
Compound 4: no number, only a limit; the forecaster's own chance of this, stated with the estimate: 70%; the middle value lies beyond the limit too.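

Compound 4, with 2,5-dichlorophenyl on the aromatic nitrogen, joins compound 1 and compound 2 at a limit of the assay, not a number, in this assay: the limit of > 50000 nM in this assay, at which 3 of the 4 values shown sit.

The steps to compound 4 from compound 1 and from compound 2 cannot be read, and the remaining step, an at least 1.1-fold higher number from compound 3 to compound 4 (0.07 log units; that floor lies within the scatter), tells nothing beyond the scatter. A second chlorine on this phenyl group therefore adds no readable difference, and this assay still separates none of the four compounds.

On these data alone, it remains open whether any group on this aromatic nitrogen can give a clear number in this assay, for example a phenyl ring bearing a carboxylic acid or an amine, or a longer alkyl chain in place of the phenyl ring. As far as these compounds go, all four compounds share the same core and the same link to the five-membered ring, so what a change in either would do also stays open.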